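Hydroxy to Carboxy on the Shared Core: Compound 3

The compounds below may be only part of what the source reports. "The series", "measured", "known", "first", "only" and "open" are said of these compounds alone.

Compound 1 `Cc1ccc2nc(C(=O)Nc3c(F)cc(-c4cccc(F)c4)cc3F)c(C)c(O)c2c1` gives 1.52% in a functional assay on Hep 3B2 cells (Homo sapiens) for antiproliferative activity, read by MTT assay, with a stated time of 24 h, tested at 0.05 ug/mL; a higher number here means a stronger effect of the compound at the concentration tested, a lower number a weaker effect.
Compound 2 `CCOc1ccc2nc(C(=O)Nc3c(F)cc(-c4cccc(F)c4)cc3F)c(C)c(O)c2c1` gives -0.04%.

Among the two measured numbers compound 1 stands highest, though the gap to compound 2 is small: the step of a number 1.6 percentage points lower from compound 1 to compound 2 (within the scatter) lies within the scatter, so the two compounds cannot be told apart. Compound 3 `Cc1ccc2nc(C(=O)Nc3c(F)cc(-c4cccc(F)c4)cc3F)c(C)c(C(=O)O)c2c1` differs from compound 1 in one place: carboxy in place of hydroxy on an aromatic carbon. Among the measured compounds shown here, no measured step touches this position; the only measured step, from methyl to ethoxy on an aromatic carbon, is not informative about a change at the hydroxy, and that step was itself within the scatter. For the measured compounds named here, with both measured values close to zero and no step of any size on record, compound 3 is expected to stay near the same level, giving a step of a number 1.5 percentage points higher from compound 1 to compound 3 (within the scatter). The estimate for compound 3 is 3%, with a range from -10% to 16%.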

Compound 3, a percentage reported as inhibition, at one concentration (the size of the read-out at that concentration, not a potency): 2.11%
Estimate against measurement, compound 3: 0.9 percentage points above; the range from low to high includes it.
By their numbers in this assay, from the lowest: compounds 2, 1 and 3 (each within the scatter of the next).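

The position opposite the ring nitrogen now has a measured step of its own in this assay: a number 0.6 percentage points higher from compound 1 to compound 3 (within the scatter). Carboxy in place of hydroxy on an aromatic carbon therefore cannot be told apart from the starting compound at this position, although the entering group is the larger of the two. Nothing measured here bears on why the read-out does not separate at this position.

Since the compounds shown all lie close to zero at a single concentration, they leave open whether any change at this position can produce a clear effect. An amine, a methoxy group or a longer chain in place of hydroxy might still move the read-out beyond the scatter, and whether hydroxy and carboxy differ at a higher concentration is also unresolved.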